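The compounds below may be only part of what the source reports. "The series", "measured", "known", "first", "only" and "open" are said of these compounds alone.

Compound 2 `COc1ccc(C2CC(c3cc(Cl)c(C)cc3O)=NN2c2ccc(S(N)(=O)=O)cc2)cc1OC` gives 3970 nM in a functional assay on TK-10 cells (Homo sapiens) for antiproliferative activity, with a stated time of 48 h (on this read-out higher numbers stand for weaker inhibition of growth and lower numbers for stronger inhibition of growth), the lower of the two numbers measured, while compound 1 `Cc1cc(O)c(C2=NN(c3ccc(S(N)(=O)=O)cc3)C(/C=C/c3ccccc3)C2)cc1Cl` gives 14800 nM. Going by the values given here, the single measured step, a 3.7-fold lower number from compound 1 to compound 2 (0.57 log units; beyond the scatter), exchanged the whole group on the saturated ring carbon rather than a substituent on that group, so it bears only loosely on the next change. Compound 3 `COc1ccc(C2CC(c3cc(Cl)c(C)cc3O)=NN2c2ccc(S(N)(=O)=O)cc2)c(OC)c1OC` differs from compound 2 by methoxy in place of hydrogen on an aromatic carbon. Among the compounds with values here, since no measured step of this kind exists, no change beyond the scatter is expected. The estimated step is a 1.1-fold lower number from compound 2 to compound 3 (0.05 log units; within the scatter). Compound 3 is expected to give about 3500 nM, between 1200 nM and 10000 nM.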

Compound 3, concentration for 50% growth inhibition: 2600 nM
Compound 3: middle estimate off by 1.3-fold (0.13 log units), on the high side, and the stated range covers the measured number.
By their numbers in this assay, from the lowest: compounds 3 and 2 (each within the scatter of the next); then compound 1.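

In this assay, methoxy in place of hydrogen on this aromatic carbon, ortho to a large group and to a methoxy group, gives a 1.5-fold lower number from compound 2 to compound 3 (0.18 log units; within the scatter) and so does not separate 2,3,4-trimethoxyphenyl from 3,4-dimethoxyphenyl. Replacing 2-phenylethenyl on the saturated ring carbon with 2,3,4-trimethoxyphenyl gives a 5.7-fold lower number from compound 1 to compound 3 (0.76 log units; beyond the scatter) with the added methoxy in place. Nothing available explains these numbers. Still open, as far as these compounds go, is how a hydroxyl or an amine would read on this aromatic carbon. From the compounds shown here alone, a longer chain, such as ethoxy in place of this methoxy, also remains open.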